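This account rests on a few compounds, and the source may have more. Where it says the series, first, only, none or still open, it means among the compounds named here.

Measured so far:
Compound 1, `COc1cc(/C=C/C2=CC(=O)CC(c3ccc(O)c(OC)c3)N2CCCO)ccc1O`: > 100000 nM
Compound 2, `COc1cc(/C=C/C(=O)/C=C(/C=C/c2ccc(O)c(OC)c2)NCCCO)ccc1O`: > 100000 nM

Both compounds were tested in a toxicity assay on EA.hy 926 cells (Homo sapiens) for cytotoxicity, read by MTT assay, with a stated time of 48 h; on this read-out lower numbers stand for stronger inhibition and higher numbers for weaker inhibition. Compound 1 produced no number there, only a limit, > 100000 nM. Compound 2 likewise produced only a limit, > 100000 nM. So compound 2 stands at the edge of what this assay can report, and the one piece of evidence about the pair is the limit of > 100000 nM in this assay, at which 2 of the 2 values shown sit. Compound 3, `COCCCNC(=C\C(=O)/C=C/c1ccc(O)c(OC)c1)/C=C/c1ccc(O)c(OC)c1`, has not yet been tested. It differs from compound 2 by methyl in place of hydrogen on an oxygen on a saturated carbon; read one bond further out, this is hydroxy to methoxy on the saturated chain. Among the compounds with values here, no measured step between compounds exists, so the expectation rests on the two limits alone: the change is expected to give a step that the limit leaves unreadable from compound 2 to compound 3, no step beyond the scatter. Compound 3 is therefore expected to give 150000 nM in this assay, within 50000 nM to 450000 nM, most likely reported again only as a limit.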

Compound 3, half-maximal inhibitory concentration in the EA.hy 926 assay: > 100000 nM
Compound 3: a limit, no number; the forecaster's own chance of this, stated with the estimate: 85%; the middle value does not contradict the limit.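

Within the data shown here, in the EA.hy 926 assay compound 2 and compound 3 both give only limits, so no step between them can be read. In a physicochemical assay for solubility, using the shake flask method, in phosphate buffer, with a stated time of 90 min, at pH 6.8 (on this read-out higher numbers stand for higher solubility and lower numbers for lower solubility), compound 2 gives 25400 nM and compound 3 gives 7700 nM. That is a 3.3-fold lower number from compound 2 to compound 3 (0.52 log units; beyond the scatter). Still open, going by these compounds, is whether any of the three compounds has a measurable effect in the EA.hy 926 assay at all.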